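The source may report more compounds than this note shows. Statements on the series, on what has been measured and on what is new or still open speak of the compounds shown alone.

Compound 1, `CC(=O)N1CCN(S(=O)(=O)c2ccc(F)cc2)CC1`, gives 0.01 mg/kg.
Compound 2, `CCC(=O)N1CCN(S(=O)(=O)c2ccc(F)cc2)CC1`, gives 0.01 mg/kg.
Compound 3, `CC(=O)NCC1CCCN(S(=O)(=O)c2ccc(F)cc2)C1`, gives 10 mg/kg.

All three were tested in a functional assay on the whole organism with Mus musculus as the target, with a stated time of 30 min (a higher number here means that more compound is needed for the effect, a lower number that less compound is needed), and all carry the same sulfonyl-linked fluorophenyl group on a saturated nitrogen ring. Compound 1 and compound 2 share one core; compound 3 has a different core, and the difference between the two cores is not broken down here. What is clear from the numbers alone is that compound 3 stands well apart: its value in this assay is the highest of the three, far beyond the usual scatter, so much more of compound 3 is needed than of either compound 1 or compound 2.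

Within the first pair, the change from compound 1 to compound 2 is methyl in place of hydrogen on a saturated chain carbon bound to a carbonyl carbon. That change gave no change at the digits printed from compound 1 to compound 2 (within the scatter).

Compound 4, `CCC(=O)NCC1CCCN(S(=O)(=O)c2ccc(F)cc2)C1`, has not yet been measured. It is built from compound 3 by methyl in place of hydrogen on a saturated chain carbon bound to a carbonyl carbon, the same change that turned compound 1 into compound 2. Because that change gave no change at the digits printed from compound 1 to compound 2 (within the scatter), the expectation for the step from compound 3 to compound 4 is likewise small, about no change at the digits printed from compound 3 to compound 4 (within the scatter). On that basis compound 4 is estimated to give about 10 mg/kg in this assay, most likely between 3 mg/kg and 30 mg/kg.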

Compound 4, minimum effective dose: 10 mg/kg
Estimate against measurement, compound 4: no gap at the digits printed; low and high end bracket the measured number.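

In this assay, turning the acetyl group of compound 3 into a propanoyl group, which means placing a methyl on a saturated chain carbon bound to a carbonyl carbon, gave no change at the digits printed from compound 3 to compound 4 (within the scatter). Set beside the earlier step, the same small addition behaves alike on both cores: the same change on two cores in this assay, no change at the digits printed (within the scatter) from compound 1 to compound 2 and no change at the digits printed (within the scatter) from compound 3 to compound 4, 1.0-fold (0.00 log units) apart, within the scatter of two such steps

Among these compounds, this shows that, on these two cores, the change carried over from one to the other without a shift that stands out from ordinary measurement noise, but it rests on only two pairs and cannot promise the same on a third core, nor does it explain why the added methyl makes no visible difference.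

The compounds shown stop at propanoyl, so it remains open whether a longer chain such as butanoyl would stay just as flat on either core, and what an amine or a carboxylic acid would do in place of the added methyl. The sulfonyl-linked fluorophenyl group is also the same in all four compounds, which leaves open how either core would respond to a swap there, such as chlorine in place of fluorine.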